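Compound 1 to compound 4: fluoro to hydrogen

The compounds below may be only part of what the source reports. "The series", "measured", "known", "first", "only" and "open" are said of these compounds alone.

Compound 1 `CNC(=O)[C@]12C[C@@H]1[C@@H](n1cnc3c(NCc4cccc(Cl)c4)nc(C#Cc4ccc(F)cc4)nc31)[C@H](O)[C@@H]2O` was tested in an assay on isolated protein for binding affinity to adenosine receptor A3 (Homo sapiens); a higher number here means a weaker inhibitor, a lower number a stronger inhibitor. For compound 1 the reported value >= 99 nM is a limit of the assay, not a number. Compound 2 `CNC(=O)[C@]12C[C@@H]1[C@@H](n1cnc3c(N[C@H]4C[C@@H]4c4ccc(F)c(F)c4)nc(C#Cc4cccc(F)c4)nc31)[C@H](O)[C@@H]2O` likewise gives only a limit in this assay, >= 99 nM. Compound 3 `CCOC(=O)[C@]12C[C@@H]1[C@@H](n1ccc3c(NCCCc4ccc(OC)c(O)c4)nc(C#Cc4ccccc4)nc31)[C@H](O)[C@@H]2O` also stops at a limit in this assay, >= 99 nM. All three values therefore share (the limit of >= 99 nM in this assay, at which 3 of the 3 values shown sit), so compound 1 cannot be placed relative to the others. Compound 4 `CNC(=O)[C@]12C[C@@H]1[C@@H](n1cnc3c(NCc4cccc(Cl)c4)nc(C#Cc4ccccc4)nc31)[C@H](O)[C@@H]2O` is unmeasured in this assay. It differs from compound 1 by hydrogen in place of fluoro on an aromatic carbon; cut one bond further out, this reads 4-fluorophenyl to phenyl. Going by the values given here, no measured step shows how such a change moves this assay. The step is expected to be small, a step that the limit leaves unreadable from compound 1 to compound 4, with a limit likely again. For compound 4 the estimate in this assay is 300 nM, between 99 nM and 3000 nM.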

Compound 4, inhibition constant: >= 99 nM
Compound 4: only a limit was reported; the forecaster's own chance of this, stated with the estimate: 70%; the middle value lies beyond the limit too.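

Going by these compounds alone, compound 4 gives only a limit in this assay, so no step from compound 1 to compound 4 can be read: the limit of >= 99 nM in this assay, at which 4 of the 4 values shown sit. The compounds shown leave open whether 4-fluorophenyl to phenyl shifts this assay at all, and how the four compounds rank.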